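A Second Methoxy Added to Compound 2

The source may report more compounds than this note shows. Statements on the series, on what has been measured and on what is new or still open speak of the compounds shown alone.

Compound 1 `O=C1C=CCC(/C=C/c2ccc(C(F)(F)F)cc2)N1` gives 150 uM in a functional assay on NCI-H460 cells (Homo sapiens) for inhibition, read by sulforhodamine B assay, with a stated time of 48 h; on this read-out higher numbers stand for weaker inhibition of growth and lower numbers for stronger inhibition of growth. Compound 2 `COc1ccc(/C=C/C2CC=CC(=O)N2)cc1` reaches in this assay only the limit of the assay, > 1090 uM. The one measured step, an at least 7.2-fold higher number from compound 1 to compound 2 (0.86 log units; beyond the scatter), ends at that limit (the limit of > 1090 uM in this assay, at which 1 of the 2 values shown sits), so compound 2 stands at the weak end of the numbers shown. Compound 3 `COc1ccc(/C=C/C2CC=CC(=O)N2)cc1OC` differs from compound 2 by methoxy in place of hydrogen on an aromatic carbon. For the measured compounds named here, no measured step matches this change; the only guide is that compound 2 already sits at the limit. Compound 3 is therefore expected to stay near that limit, a step that the limit leaves unreadable from compound 2 to compound 3. The estimate for compound 3 is 1200 uM, between 500 uM and 3000 uM.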

Compound 3, concentration for growth inhibition (reported as GI): > 964 uM
Compound 3: no number, only a limit; the forecaster's own chance of this, stated with the estimate: 75%; the middle value does not contradict the limit.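

In this assay compound 3 gives > 964 uM, a limit and not a number. Compound 2 gives > 1090 uM, also a limit. For the compounds shown here, no step between compound 2 and compound 3 can be read. On these data alone, whether the added methoxy changes growth inhibition stays open.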